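From Cyclohexyl to Phenyl on the Amide Nitrogen

The source may report more compounds than this note shows. Statements on the series, on what has been measured and on what is new or still open speak of the compounds shown alone.

Of the compounds shown here, three sharing one core have been tested in a toxicity assay on GES1 cells (Homo sapiens) for inhibition, read by CCK-8 assay, with a stated time of 72 h; a higher number here means a weaker inhibitor, a lower number a stronger inhibitor. Compound 1 `CC(C)(C)OC(=O)N1CCN(C(=O)Cn2cc(CN3C(=O)C(=O)c4c(Cl)ccc(Cl)c43)nn2)CC1` gives 84200 nM in this assay. Compound 2 `O=C(Cn1cc(CN2C(=O)C(=O)c3c(Cl)ccc(Cl)c32)nn1)OC1CCCCC1` gives 36000 nM, and compound 3 `O=C(Cn1cc(CN2C(=O)C(=O)c3c(Cl)ccc(Cl)c32)nn1)NC1CCCCC1` gives 47400 nM. All three numbers sit close together, and compound 3 stands apart from neither neighbour. Compound 4 `O=C(Cn1cc(CN2C(=O)C(=O)c3c(Cl)ccc(Cl)c32)nn1)Nc1ccccc1` differs from compound 3 by phenyl in place of cyclohexyl on an amide-type nitrogen. Among the measured compounds shown here, no measured step bears directly on this change. For the measured compounds named here, the only single-point step measured so far, a 1.3-fold higher number from compound 2 to compound 3 (0.12 log units; within the scatter), touches the same position but alters the linking atom, not the ring, and stayed within the scatter. The expectation is therefore a step of a 1.1-fold lower number from compound 3 to compound 4 (0.02 log units; within the scatter), nothing beyond the scatter. Compound 4 is estimated at 45000 nM, within a range from 18000 nM to 110000 nM.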

Compound 4, half-maximal inhibitory concentration: 24900 nM
Compound 4: the middle estimate sits 1.8-fold (0.26 log units) above what was measured, and the stated range covers the measured number.
By their numbers in this assay, from the lowest: compounds 4, 2, 3 and 1 (each within the scatter of the next, the first and the last beyond it).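

In this assay, phenyl in place of cyclohexyl gives a 1.9-fold lower number from compound 3 to compound 4 (0.28 log units; within the scatter) on the amide-type nitrogen, so an aromatic ring is accommodated here as well as a non-aromatic one. Anilino in place of cyclohexyloxy gives a 1.4-fold lower number from compound 2 to compound 4 (0.16 log units; within the scatter) on the carbonyl carbon, so changing the ring and the linking atom together also stays within the scatter. Nothing measured here gives a reason for either step. Still open, as far as these compounds go, is what a longer chain on this nitrogen, or a phenyl ring carrying an amine or a carboxylic acid, would do.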